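Working notes: 4-nitrophenyl to 4-bromophenyl

The compounds below may be only part of what the source reports. "The series", "measured", "known", "first", "only" and "open" are said of these compounds alone.

Measured so far in a functional assay on SMMC-7721 cells (Homo sapiens) for cytotoxicity, read by MTT assay, with a stated time of 24 h; a higher number here means a weaker inhibitor, a lower number a stronger inhibitor:
- compound 1 `CN1C/C(=C\c2ccncc2)C(=O)/C(=C/c2ccccc2F)C1` gives 7000 nM
- compound 2 `O=C1/C(=C/c2ccncc2)CN(S(=O)(=O)c2ccc([N+](=O)[O-])cc2)C/C1=C\c1ccccc1F` gives 15800 nM

Of these two numbers, compound 2 (15800 nM) has the higher, meaning the weaker inhibition, and the gap to compound 1 (7000 nM) lies beyond the scatter. The two compounds differ in more than one place, so their gap is not a measure of any single change.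

Compound 3 `O=C1/C(=C/c2ccncc2)CN(S(=O)(=O)c2ccc(Br)cc2)C/C1=C\c1ccccc1F` comes from compound 2 by one change, bromo in place of nitro on an aromatic carbon para to a large group. Within the data shown here, no measured pair shows this exchange, so no step beyond the scatter is expected in this assay and only a slight drop is assumed. The estimate is anchored on compound 2 (15800 nM). For compound 3 the estimated value is 12000 nM (expected range 5000 nM to 28000 nM) in this read-out. The expected 1.3-fold lower number from compound 2 to compound 3 (0.12 log units; within the scatter) stays within the scatter.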

Compound 3, half-maximal inhibitory concentration: 12600 nM
Compound 3: the middle estimate sits 1.1-fold (0.02 log units) below what was measured; the range from low to high includes it.
By their numbers in this assay, from the lowest: compounds 1, 3 and 2 (each within the scatter of the next, the first and the last beyond it).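

In this assay bromo in place of nitro on an aromatic carbon, para to a large group, gives a 1.3-fold lower number from compound 2 to compound 3 (0.10 log units; within the scatter) and so shows that this position accepts the exchange with no readable shift, although the group entering has fewer heavy atoms and no hydrogen-bond acceptors. Among these compounds, the first single-place comparison at the amine nitrogen in the ring, (4-bromophenyl)sulfonyl in place of methyl, gives a 1.8-fold higher number from compound 1 to compound 3 (0.26 log units; within the scatter) and also stays inside the scatter, so neither exchange separates these compounds in this read-out. No measurement at hand bears on what lies behind these numbers.

On these data alone, whether an amine or a carboxylic acid on the same aromatic carbon would move the number beyond the scatter remains open. So does whether a longer chain on the ring nitrogen would do so.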